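A Second Chloro Substituent Across Two Related Cores

The source may hold more compounds than are shown below. What is called first, only, known or untested is meant among the compounds shown, and "the series" means these compounds.

Compound 1 `ClCc1cccc(Cn2cnc3c(Cl)ncnc32)c1` gives 12300 nM.
Compound 2 `ClCc1cccc(Cn2cnc3c(Cl)nc(Cl)nc32)c1` gives 4460 nM.
Compound 3 `ClCc1ccccc1Cn1cnc2ncnc(Cl)c21` gives 4260 nM.

All three were tested in a functional assay on T47D cells (Homo sapiens) for cytotoxicity, read by sulforhodamine B assay, with a stated time of 48 h; a higher number here means a weaker inhibitor of growth, a lower number a stronger inhibitor of growth. The change from compound 1 to compound 2 is chloro in place of hydrogen on an aromatic carbon, and it produced a 2.8-fold lower number from compound 1 to compound 2 (0.44 log units; beyond the scatter). Compound 3 has the same atoms as compound 1, joined differently; the difference between the two cores is not broken down here. The values of compound 3 and compound 2 lie within the scatter of one another, so nothing separates them.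

Compound 4 `ClCc1ccccc1Cn1cnc2nc(Cl)nc(Cl)c21` has not been measured. It differs from compound 3 by chloro in place of hydrogen on an aromatic carbon, the same change that turned compound 1 into compound 2. Because compound 1 to compound 2 gave a 2.8-fold lower number from compound 1 to compound 2 (0.44 log units; beyond the scatter), a step of similar size is expected for compound 4, namely a 2.7-fold lower number from compound 3 to compound 4 (0.43 log units; beyond the scatter). The expectation rests on a single earlier instance, so it is held loosely. Compound 4 is therefore estimated at 1600 nM, with a range from 700 nM to 4000 nM.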

Compound 4, concentration for total growth inhibition: 5240 nM
Compound 4: middle estimate off by 3.3-fold (0.52 log units), on the low side; measured number above the stated range.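

On the core of compound 3, chloro in place of hydrogen on an aromatic carbon, between two ring nitrogen atoms, gave a 1.2-fold higher number from compound 3 to compound 4 (0.09 log units; within the scatter) in this assay, so the step seen on the core of compound 1 did not recur here. The two instances of this one change do not agree: the same change on two cores in this assay, a 2.8-fold lower number (0.44 log units; beyond the scatter) from compound 1 to compound 2 and a 1.2-fold higher number (0.09 log units; within the scatter) from compound 3 to compound 4, 3.4-fold (0.53 log units) apart, beyond the scatter of two such steps. Among these compounds, this shows that, in this series, the effect of the change cannot be assumed to carry from one core to the other, but with only one pair on each core it does not show which difference between the cores sets the two steps apart, or what the change would do on any further core.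

Going by these compounds, it remains open whether a different group on that same carbon, such as an amine or a methoxy group, would also part between the two cores. Also open, on these data alone, is whether the two cores would keep this difference if the chloromethyl group gave way to a hydroxymethyl group or a longer chain.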